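The compounds below may be only part of what the source reports. "The series", "measured", "known", "first", "only" and "open" are said of these compounds alone.

Compound 1 `CC1CC/C(=N\Nc2cccc(Cl)c2)c2ncc(C(=O)O)c(=O)n21` gives 0.6 umol/kg in a functional assay on the whole organism for inhibition, with Rattus norvegicus as the target; on this read-out lower numbers stand for an effect already at smaller amounts and higher numbers for an effect only at larger amounts of compound.
Compound 2 `CC1CC/C(=N\Nc2ccc(Cl)cc2)c2ncc(C(=O)O)c(=O)n21` gives 0.5 umol/kg in this assay.
Compound 3 `CC1CC/C(=N\Nc2ccccc2O)c2ncc(C(=O)O)c(=O)n21` gives 0.26 umol/kg in this assay.

Among these three numbers compound 2 stands second highest. Its nearest neighbour is reached by a 1.2-fold lower number from compound 1 to compound 2 (0.08 log units; within the scatter), a step within the scatter, and its furthest by a 1.9-fold lower number from compound 2 to compound 3 (0.28 log units; within the scatter), also within the scatter. Going by the values given here, the only step beyond the scatter is a 2.3-fold lower number from compound 1 to compound 3 (0.36 log units; beyond the scatter), and it is modest.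

Compound 4 `CC1CC/C(=N\Nc2ccc(-c3ccccc3)cc2)c2ncc(C(=O)O)c(=O)n21` has not yet been measured in this assay. It differs from compound 2 by phenyl in place of chloro on an aromatic carbon. Among the compounds with values here, none of the measured steps exchanges a chloro for a phenyl; all three keep a single small substituent on the ring attached to the amine nitrogen and merely move or exchange it, and two of them stay within the scatter. The data give no basis for a large step in either direction, so compound 4 is expected to land close to compound 2, with a 1.4-fold higher number from compound 2 to compound 4 (0.15 log units; within the scatter) the expected step. Compound 4 is therefore estimated at 0.7 umol/kg, with a range from 0.25 umol/kg to 2 umol/kg.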

Compound 4, dose for 50% inhibition: 1.1 umol/kg
Compound 4: the middle estimate sits 1.6-fold (0.20 log units) below what was measured; the measured number falls inside the stated range.
By their numbers in this assay, from the lowest: compounds 3, 2, 1 and 4 (each within the scatter of the next, the first and the last beyond it).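

In this assay, exchanging chloro (one heavy atom) for phenyl (six heavy atoms) on an aromatic carbon para to a large group gives a 2.2-fold higher number from compound 2 to compound 4 (0.34 log units; beyond the scatter). Unlike moving the chlorine, which gave a 1.2-fold lower number from compound 1 to compound 2 (0.08 log units; within the scatter), this exchange at the same ring produces a step beyond the scatter, though only a modest one, so this position takes a whole added aromatic ring without a large change in the read-out. Nothing available explains this step.

The compounds shown leave open whether the number keeps rising with group size at this position, as a single pair cannot separate size from the other differences between chloro and phenyl. From the compounds shown here alone, how a methyl, a methoxy, an amine or a longer chain would behave here also remains open, as does the effect of substituents on the added phenyl.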